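This account rests on a few compounds, and the source may have more. Where it says the series, first, only, none or still open, it means among the compounds named here.

Three compounds have so far been measured in a functional assay on HepG2 cells (Homo sapiens) for cytotoxicity, with a stated time of 24 h; on this read-out higher numbers stand for weaker inhibition and lower numbers for stronger inhibition:

compound 1 (`O=C(N/N=C/c1cc(I)cc(I)c1O)c1ccc(O)cc1`), giving 19200 nM
compound 2 (`O=C(N/N=C/c1cc(I)cc(I)c1O)c1ccc(I)cc1`), giving 31800 nM
compound 3 (`COc1ccc(C(=O)N/N=C/c2cc(I)c(O)c(I)c2)cc1`), for which only a limit is known, > 100000 nM

Compound 3 thus stands at the edge of what this assay reports: its result is one of those at the limit of > 100000 nM in this assay, at which 1 of the 3 values shown sits, so it is a bound rather than a number, and it can only be said that compound 3 is weaker than compounds 1 and 2 on this read-out.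

Compound 4 (`O=C(N/N=C/c1cc(I)c(O)c(I)c1)c1ccc(Br)cc1`) differs from compound 3 by bromo in place of methoxy on an aromatic carbon. Among the compounds with values here, the one measured step that bears on this is a 1.7-fold higher number from compound 1 to compound 2 (0.22 log units; within the scatter), where an oxygen substituent on the same ring likewise gave way to a halogen; that step stayed within the scatter. An exchange of methoxy for bromo is therefore expected to leave the number about where it is, with no step beyond the scatter. Compound 4 is accordingly expected at 100000 nM, most plausibly again as a limit, with a range from 40000 nM to 300000 nM, which amounts to an expected step of a number no higher from compound 3 to compound 4 (the limit leaves the size open).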

Compound 4, half-maximal inhibitory concentration: > 50000 nM
Compound 4: no number, only a limit; the forecaster's own chance of this, stated with the estimate: 60%; the middle value is on the limit's open side.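

In this assay compound 3 and compound 4 are both known only as limits, so no step can be read between them. The compounds shown leave open how large a change bromo in place of methoxy makes on this read-out, and in which direction.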